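The source may report more compounds than this note shows. Statements on the series, on what has been measured and on what is new or still open speak of the compounds shown alone.

In an ADME assay on HEK-293T cells (Homo sapiens) for cytotoxicity, read by luminescence and CellTiter-Glo, with a stated time of 24 h (a higher number here means that more compound is tolerated, a lower number that less compound is tolerated), compound 1 `CCCNC(=O)C1CCN(C(=O)c2cc3scnc3n2Cc2ccc(OC)cc2)CC1` gives 19100 nM and compound 3 `CCCNC(=O)C1CCN(C(=O)c2cc3sc(-c4ccccc4)nc3n2Cc2ccc(OC)cc2)CC1` gives 22900 nM, so these two numbers lie within the scatter of each other. Compound 2 `CCCNC(=O)[C@H]1CC[C@@H](NC(=O)c2cc3sc(Br)cc3n2Cc2ccc(OC)cc2)CC1` reads > 100000 nM, which is a limit of the assay and not a number.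

Compound 4 `CCCNC(=O)C1CCN(C(=O)c2cc3sc(Br)nc3n2Cc2ccc(OC)cc2)CC1` differs from compound 3 by one change: bromo in place of phenyl on an aromatic carbon. Going by the values given here, the one measured step on that same carbon is a 1.2-fold higher number from compound 1 to compound 3 (0.08 log units; within the scatter), with phenyl in place of hydrogen. Among the compounds with values here, compound 2 also carries bromo but differs from compound 4 in other places as well, and no step links the two. Bromo on the core of compound 1 has no measurement yet.

With only a 1.2-fold higher number from compound 1 to compound 3 (0.08 log units; within the scatter) to go on, no step beyond the scatter is expected in this assay. The expected change is a 1.1-fold higher number from compound 3 to compound 4 (0.04 log units; within the scatter). The estimate for compound 4 is 25000 nM, with an expected range from 10000 nM to 65000 nM.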

Compound 4, half-maximal cytotoxic concentration: 36700 nM
Compound 4: the middle estimate sits 1.5-fold (0.17 log units) below what was measured, within the range that was stated.
By their numbers in this assay, from the lowest: compounds 1, 3 and 4 (each within the scatter of the next). At a limit, above all of these: compound 2.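

At this aromatic carbon, next to the ring nitrogen and next to the ring sulfur, this assay now covers hydrogen, phenyl and bromo on the shared core. Bromo in place of phenyl gives a 1.6-fold higher number from compound 3 to compound 4 (0.20 log units; within the scatter) and bromo in place of hydrogen gives a 1.9-fold higher number from compound 1 to compound 4 (0.28 log units; within the scatter) so that a single bromine, like the six-membered aromatic ring of carbon only, makes no step beyond the scatter at this position. No measured property in hand bears on these steps.

From the compounds shown here alone, whether an amine or a carboxylic acid on this carbon would give a step beyond the scatter remains open. Compound 2 reads > 100000 nM which is a limit of the assay, and because it differs from compound 4 in more than one place, what sets that reading apart stays unresolved.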